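The compounds below may be only part of what the source reports. "The series", "measured", "known", "first", "only" and "open" are said of these compounds alone.

Measured in a functional assay on MCF7 cells (Homo sapiens) for inhibition, read by fluorescence, with a stated time of 72 h; on this read-out lower numbers stand for stronger inhibition and higher numbers for weaker inhibition:
- compound 1 `CC[C@H](CO)Nc1nc(NC(=N)N)c2ncn(C(C)C)c2n1`: 4500 nM
- compound 2 `CC[C@H](N)COc1nc(NC(=N)N)c2ncn(C(C)C)c2n1`: 16300 nM
- compound 3 `CC[C@@H](CO)Nc1nc(NC(=N)N)c2ncn(C(C)C)c2n1`: 1600 nM

Compound 3, at 1600 nM, has the lowest number of the three, and its steps to both others lie beyond the scatter. Next in line is compound 4 `CC(C)[C@H](CO)Nc1nc(NC(=N)N)c2ncn(C(C)C)c2n1`, not yet measured in this assay. The change is 1-(hydroxymethyl)-2-methylpropyl in place of 1-(hydroxymethyl)propyl on a nitrogen on an aromatic ring.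

Among the measured compounds shown here, no measured step covers this exact change. The closest is a 2.8-fold lower number from compound 1 to compound 3 (0.45 log units; beyond the scatter), which alters the same chain only at its stereocentre. Less close is a 10-fold lower number from compound 2 to compound 3 (1.01 log units; beyond the scatter), which swaps (1-(hydroxymethyl)propyl)amino for 2-aminobutoxy. For the measured compounds named here, both show that the number responds to this part of compound 3, and every other compound so far sits higher than compound 3, so a modest rise is expected rather than a further fall. The expected change is a 1.9-fold higher number from compound 3 to compound 4 (0.27 log units; within the scatter). Compound 4 is estimated at 3000 nM, with an expected range of 900 nM to 10000 nM.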

Compound 4, half-maximal inhibitory concentration: 10500 nM
Beside the measured number, compound 4's estimate is 3.5-fold (0.54 log units) below it; measured number above the stated range.
By their numbers in this assay, from the lowest: compound 3; then compound 1; then compounds 4 and 2 (each within the scatter of the next).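

In this assay the side chain on this nitrogen responds to its size as well as to its configuration: 1-(hydroxymethyl)-2-methylpropyl in place of 1-(hydroxymethyl)propyl gives a 6.6-fold higher number from compound 3 to compound 4 (0.82 log units; beyond the scatter), and methyl in place of hydrogen on the chain gives a 2.3-fold higher number from compound 1 to compound 4 (0.37 log units; beyond the scatter). The number therefore rises from both compounds that carry the shorter chain, so the added carbon is not neutral here. The edge that (1-(hydroxymethyl)propyl)amino holds over 2-aminobutoxy does not carry over to (1-(hydroxymethyl)-2-methylpropyl)amino, which gives a 1.6-fold lower number from compound 2 to compound 4 (0.19 log units; within the scatter), so no order can be read between these two.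

Nothing shown accounts for the rise at this position. From the compounds shown here alone, how a carboxylic acid or an amine in place of the hydroxymethyl, or a longer unbranched chain, would read here remains open.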